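The compounds below may be only part of what the source reports. "The series", "measured", "known", "first", "only" and "open" are said of these compounds alone.

In a functional assay on U-937 cells (Homo sapiens) for cytotoxicity, read by MTT assay, with a stated time of 72 h (on this read-out lower numbers stand for stronger inhibition and higher numbers for weaker inhibition), compound 1 `CC(=O)O[C@H](C/C(C)=C/CO)[C@@]1(C)[C@H](C)CC=C2[C@@H]1CCCC2(C)C` reads > 30000 nM, which is a limit and not a number. Compound 2 `CCC(=O)OC/C=C(\C)C[C@@H](O)[C@@]1(C)[C@H](C)CC=C2[C@@H]1CCCC2(C)C` gives a measured 24700 nM. Compound 3 `C/C(=C\COC(=O)c1ccccc1)C[C@@H](O)[C@@]1(C)[C@H](C)CC=C2[C@@H]1CCCC2(C)C` reads > 30000 nM, which is also a limit. Compound 3 therefore stands at the limit of > 30000 nM in this assay, at which 2 of the 3 values shown sit, with no number of its own.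

The next change leads to compound 4 `C/C(=C\CO)C[C@@H](O)[C@@]1(C)[C@H](C)CC=C2[C@@H]1CCCC2(C)C`: hydrogen in place of benzoyl on an oxygen on a saturated carbon. In words, this is hydrogen in place of benzoyl on an oxygen on a saturated carbon, or benzoyloxy to hydroxy.

Among the measured compounds shown here, one measured step bears on it: an at least 1.2-fold higher number from compound 2 to compound 3 (0.08 log units; that floor lies within the scatter), with phenyl in place of ethyl on a carbonyl carbon at the same oxygen. That step stays within the scatter. For the measured compounds named here, no measured compound carries hydrogen on this oxygen, so the precedent is only indirect. No step beyond the scatter is expected in this assay, in either direction, and a further limit reading is the likeliest result. The expected change is a number no higher from compound 3 to compound 4 (the limit leaves the size open). Compound 4 is estimated at 30000 nM, with an expected range from 15000 nM to 60000 nM.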

Compound 4, half-maximal inhibitory concentration: > 30000 nM
Compound 4 gave a limit, no number; the forecaster's own chance of this, stated with the estimate: 60%; the middle value lies on the limit itself.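

In this assay, taking the acyl group off this oxygen altogether gives an at least 1.2-fold higher number from compound 2 to compound 4 (0.08 log units; that floor lies within the scatter), so the free hydroxy form is not set apart from the propanoyl ester, though this is a floor and the true gap could be larger. The steps to compound 4 from compound 1 and from compound 3 cannot be read, as both ends of each are limits. With hydrogen now alongside propanoyl and benzoyl on this oxygen, none of the three shows a step beyond the scatter, and the set gathers at one limit: the limit of > 30000 nM in this assay, at which 3 of the 4 values shown sit.

Going by these compounds, how far the limit compounds lie past that limit stays open, and only compound 2 has a number of its own. On these data alone, what an aminoacetyl group or a longer acyl chain such as octanoyl would read on this oxygen is also open.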